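The source may report more compounds than this note shows. Statements on the series, on what has been measured and on what is new or still open speak of the compounds shown alone.

Four compounds share one core, and each carries a small chain on a ring nitrogen. Compound 1 `C=CCn1cc(C#N)c2c(N)ncnc21`, compound 2 `CCOCn1cc(C#N)c2c(N)ncnc21` and compound 3 `CCOCn1cc(C(N)=O)c2c(N)ncnc21` have been tested in a functional assay on KB cells (Homo sapiens) for cytotoxicity (on this read-out lower numbers stand for stronger inhibition and higher numbers for weaker inhibition), while compound 4 `C=CCn1cc(C(N)=O)c2c(N)ncnc21` has not. In this assay compound 1 reaches only the assay limit of > 100000 nM. Compound 2 likewise gives only the limit of > 100000 nM. Compound 3 also stops at the limit of > 100000 nM. The change from compound 2 to compound 1 is vinyl in place of ethoxy on a saturated chain carbon bound to an aromatic nitrogen; its step that the two limits leave unreadable from compound 2 to compound 1 cannot be read because of the limit of > 100000 nM in this assay, at which 3 of the 3 values shown sit. The two cores differ by carbamoyl in place of cyano on an aromatic carbon, with a step that the two limits leave unreadable from compound 2 to compound 3. Compound 4 carries the same change as compound 1, namely (vinyl in place of ethoxy on a saturated chain carbon bound to an aromatic nitrogen). The step from compound 3 to compound 4 is expected to be about a step that the limit leaves unreadable from compound 3 to compound 4, resting on the unreadable step that the two limits leave unreadable from compound 2 to compound 1. Compound 4 is therefore estimated at 200000 nM.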

Compound 4, half-maximal inhibitory concentration: 100000 nM
Compound 4: the middle estimate sits 2.0-fold (0.30 log units) above what was measured; measured number inside the range.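

In this assay, allyl in place of ethoxymethyl on the carbamoyl core gives a number no higher from compound 3 to compound 4 (the limit leaves the size open), and carbamoyl in place of cyano on the allyl core gives a number no higher from compound 1 to compound 4 (the limit leaves the size open). Going by these compounds alone, compound 4 gives 100000 nM, the only true number in the set, so carrying the change to this core brings no strong inhibition into view. Whether the change acts alike on both cores cannot be told, because neither step has a readable size: the limit of > 100000 nM in this assay, at which 3 of the 4 values shown sit.

The compounds shown leave open how an amine, a carboxylic acid or a longer chain would read in this assay in place of the allyl or ethoxymethyl chain. They also leave open whether any such group would give a value that could be compared at all.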